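The source may report more compounds than this note shows. Statements on the series, on what has been measured and on what is new or still open speak of the compounds shown alone.

In a functional assay on HL-60 cells (Homo sapiens) for antiproliferative activity, with a stated time of 72 h (a lower number here means a stronger inhibitor, a higher number a weaker inhibitor), compound 1 `CCCC#Cc1cc([C@@H]2O[C@H](CO)[C@@H](O)[C@H]2O)n2ncnc(N)c12` gives 200 nM and compound 2 `Nc1ncnn2c([C@@H]3O[C@H](CO)[C@@H](O)[C@H]3O)cc(-c3ccc(F)cc3F)c12` gives 99300 nM, the higher of the two numbers. Compound 3 `COc1ccc(-c2cc([C@@H]3O[C@H](CO)[C@@H](O)[C@H]3O)n3ncnc(N)c23)cc1` differs from compound 2 in one group: 4-methoxyphenyl in place of 2,4-difluorophenyl on an aromatic carbon. Going by the values given here, the only measured step at that carbon is a 500-fold higher number from compound 1 to compound 2 (2.70 log units; beyond the scatter), a large one that replaced pent-1-yn-1-yl. Among the compounds with values here, no measured step compares one phenyl group with another, so only a modest move toward lower numbers is expected in this assay. The expected change is a 2.5-fold lower number from compound 2 to compound 3 (0.39 log units; beyond the scatter). The estimate for compound 3 is 40000 nM, with an expected range of 5000 nM to 100000 nM.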

Compound 3, half-maximal inhibitory concentration: > 100000 nM
Compound 3 ended at the assay's limit; the forecaster's own chance of this, stated with the estimate: 35%; middle value at least 2.5-fold (0.39 log units) away from the limit.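

In this assay compound 3 gives > 100000 nM, which is a limit of the assay and not a number. Placing 4-methoxyphenyl on this aromatic carbon in place of pent-1-yn-1-yl gives an at least 500-fold higher number from compound 1 to compound 3 (2.69 log units; beyond the scatter), so the large rise seen with 2,4-difluorophenyl now recurs with a second substituted phenyl group. Placing 4-methoxyphenyl in place of 2,4-difluorophenyl gives a number no lower from compound 2 to compound 3 (the limit leaves the size open) and this step cannot be read, so the two phenyl compounds remain unranked. The compounds shown leave open whether a longer alkyne chain, a saturated alkyl chain or an amine at this carbon would give numbers near that of the pent-1-yn-1-yl compound.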